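A fluoro for methyl swap at one concentration

This account rests on a few compounds, and the source may have more. Where it says the series, first, only, none or still open, it means among the compounds named here.

In a functional assay on RS4-11 cells (Homo sapiens) for inhibition, read by CCK-8 assay, with a stated time of 48 h, tested at 20 uM (on this read-out lower numbers stand for less inhibition of growth and higher numbers for more inhibition of growth at the one concentration tested), compound 1 (`N#C/C(=C\c1ccccc1OS(=O)(=O)c1ccc(F)cc1)C(=O)Nc1nnc(Cc2ccccc2)s1`) gives 69% and compound 2 (`Cc1ccc(Cc2nnc(NC(=O)/C(C#N)=C/c3ccccc3OS(=O)(=O)c3ccc(C)cc3)s2)cc1`) gives 66% so compound 2 stands within the scatter of compound 1. Compound 3 (`Cc1ccc(Cc2nnc(NC(=O)/C(C#N)=C/c3ccccc3OS(=O)(=O)c3ccc(F)cc3)s2)cc1`) carries fluoro in place of methyl on an aromatic carbon of compound 2 (fluoro in place of methyl on an aromatic carbon). Among the compounds with values here, no measured pair shows this change. The two values at hand lie close together, so the expected step in this assay (a number 1 percentage points higher from compound 2 to compound 3 (within the scatter)) stays within the scatter, with no direction expected. Compound 3 is estimated at 67% (55% to 78%).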

Compound 3, percent growth inhibition at one concentration: 73%
The estimate for compound 3 lay 6 percentage points below the measured number, and the stated range covers the measured number.
By their numbers in this assay, from the lowest: compounds 2, 1 and 3 (each within the scatter of the next).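

In this assay, fluoro in place of methyl on the sulfonyl-bearing aromatic ring gives a number 7 percentage points higher from compound 2 to compound 3 (within the scatter), so at this position the read-out does not tell the two groups apart. The other single change, methyl in place of hydrogen on an aromatic carbon, gives a number 4 percentage points higher from compound 1 to compound 3 (within the scatter) and is likewise not resolved. Nothing at hand offers an explanation for these numbers. The compounds shown leave open whether an amine or a carboxylic acid at this position would move growth inhibition beyond the scatter.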